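Chlorophenyl positional change in a vinyl sulfonate series

The source may hold more compounds than are shown below. What is called first, only, known or untested is meant among the compounds shown, and "the series" means these compounds.

Compound 1 `COc1ccccc1OS(=O)(=O)/C=C/c1cccc(Cl)c1` gives 698 nM in an assay on U2OS cells for activation of nuclear factor erythroid 2-related factor 2 (Homo sapiens), read by chemiluminescence, with a stated time of 6 h; on this read-out higher numbers stand for an effect only at larger amounts of compound and lower numbers for an effect already at smaller amounts. Compound 3 `COc1ccccc1OS(=O)(=O)/C=C/c1ccc(Cl)cc1` differs from it by 4-chlorophenyl in place of 3-chlorophenyl on a double-bonded chain carbon bound to a double-bonded chain carbon and gives 1330 nM in this assay, a step of a 1.9-fold higher number from compound 1 to compound 3 (0.28 log units; within the scatter). Compound 2 `COc1cccc(OS(=O)(=O)/C=C/c2cccc(Cl)c2)c1` has a different core; the difference between the two cores is not broken down here. In this assay compound 2 gives 943 nM, close to the values of compound 1 and compound 3 alike. Compound 4 `COc1cccc(OS(=O)(=O)/C=C/c2ccc(Cl)cc2)c1` relates to compound 2 as compound 3 relates to compound 1: 4-chlorophenyl in place of 3-chlorophenyl on a double-bonded chain carbon bound to a double-bonded chain carbon, the same change at the same place. For the measured compounds named here, the expectation for compound 4 rests on the single measured instance of this change, the step of a 1.9-fold higher number from compound 1 to compound 3 (0.28 log units; within the scatter), applied to the value of compound 2. Compound 4 is therefore expected to show a step of a 1.9-fold higher number from compound 2 to compound 4 (0.28 log units; within the scatter), of similar size to the earlier one. Compound 4 is estimated at 1800 nM, between 800 nM and 4000 nM.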

Compound 4, half-maximal effective concentration: 1780 nM
Beside the measured number, compound 4's estimate is 1.0-fold (0.00 log units) above it; low and high end bracket the measured number.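

On the core of compound 2, 4-chlorophenyl in place of 3-chlorophenyl gives a 1.9-fold higher number from compound 2 to compound 4 (0.28 log units; within the scatter) in this assay. For the compounds shown here, the step carries over from one core to the other with no difference in size that can be told apart: the same change on two cores in this assay, a 1.9-fold higher number (0.28 log units; within the scatter) from compound 1 to compound 3 and a 1.9-fold higher number (0.28 log units; within the scatter) from compound 2 to compound 4, 1.0-fold (0.00 log units) apart, within the scatter of two such steps Each step on its own lies within the scatter, so this agreement shows only that the two cores do not separate the change; it does not establish a real difference between 3-chlorophenyl and 4-chlorophenyl, and two cores cannot support a rule for the wider series.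

Open, on these data alone, is whether the same agreement holds when the chlorine gives way to fluorine, trifluoromethyl or a nitrile. Also open, as far as these compounds go, is whether it holds on a core carrying an amine or a carboxylic acid in place of the methoxy group.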